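A few compounds are considered here, and "the series" means these few. Any claim that something is new, unique, unknown or untested is made for them only; others in the source may bear on it.

Measured in a functional assay on DU-145 cells (Homo sapiens) for inhibition, read by trypan blue exclusion, with a stated time of 96 h; a higher number here means a weaker inhibitor of growth, a lower number a stronger inhibitor of growth:
- Compound 1 `COc1cc(/C=C(/Sc2ccc(Br)cc2)C(=O)c2ccc(Br)cc2)ccc1O`: 1000 nM
- Compound 2 `COc1cc(/C=C(/Sc2ccc(Br)cc2)C(=O)c2ccc(Br)cc2)ccc1F`: 10000 nM
- Compound 3 `O=C(/C(=C\c1ccc(I)cc1)Sc1ccc(Br)cc1)c1ccc(Br)cc1`: 1000 nM

Compound 3 stands level with compound 1, and the two share the lowest number of the three. The next structure, compound 4 `O=C(/C(=C\c1ccc(F)cc1Cl)Sc1ccc(Br)cc1)c1ccc(Br)cc1`, carries 2-chloro-4-fluorophenyl in place of 4-iodophenyl on a double-bonded chain carbon bound to a double-bonded chain carbon.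

Two measured steps change this same group. One is flat, no change at the digits printed from compound 1 to compound 3 (within the scatter), while the other is not, a 10-fold lower number from compound 2 to compound 3 (1.00 log units; beyond the scatter). The group can therefore vary with or without a shift in this assay. For the measured compounds named here, the only measured compound with a fluoro-bearing group here is compound 2, at 10000 nM, and a 10-fold higher number from compound 1 to compound 2 (1.00 log units; beyond the scatter) also involves that fluoro. Going by the values given here, no measured compound carries the 2-chloro-4-fluorophenyl group, so the evidence is indirect.

Among the compounds with values here, a modest step to a higher number is expected, smaller than the one separating compound 2 from compound 3. The estimated step is a 2.5-fold higher number from compound 3 to compound 4 (0.40 log units; beyond the scatter). For compound 4 the expected value is 2500 nM, with an estimated range of 500 nM to 10000 nM.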

Compound 4, concentration for 50% growth inhibition: 1000 nM
Beside the measured number, compound 4's estimate is 2.5-fold (0.40 log units) above it; the range from low to high includes it.
By their numbers in this assay, from the lowest: compounds 1, 3 and 4 (each within the scatter of the next); then compound 2.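

In this assay the group on the double-bonded chain carbon can carry a fluoro and still stay flat, with no change at the digits printed from compound 3 to compound 4 (within the scatter) and with no change at the digits printed from compound 1 to compound 4 (within the scatter) as well. For the compounds shown here, a fluoro-bearing group at this place therefore does not by itself go with the higher number of compound 2, which stands apart (a 10-fold lower number from compound 2 to compound 4 (1.00 log units; beyond the scatter)), and compound 2 is the one compound here that goes against a flat picture at this place. No measured evidence gives a cause for any of these steps.

Still open, as far as these compounds go, is how a 4-fluorophenyl group, with neither the chloro nor the methoxy, would read at this place. Also open, from the compounds shown here alone, is whether an amine or a carboxylic acid on this ring would stay level with compound 1 in this assay or move away from it.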